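Adding dimethylamino to compound 3

The source may report more compounds than this note shows. Statements on the series, on what has been measured and on what is new or still open speak of the compounds shown alone.

Compound 1 `COc1cc(/C=C/C(=O)C2=C(/C=C/c3ccc(O)c(OC)c3)NC(=O)NC2c2ccc(C)cc2)ccc1O` gives 100000 nM
Compound 2 `COc1cc(/C=C/C(=O)C2=C(/C=C/c3ccc(O)c(OC)c3)NC(=O)NC2c2ccc(N(C)C)cc2)ccc1O` gives 12500 nM
Compound 3 `COc1cc(/C=C/C(=O)C2=C(/C=C/c3ccc(O)c(OC)c3)NC(=S)NC2c2ccccc2)ccc1O` gives 100000 nM

In a functional assay on QG-56 cells (Homo sapiens) for cytotoxicity, read by MTT assay, with a stated time of 48 h (on this read-out lower numbers stand for stronger inhibition and higher numbers for weaker inhibition), compound 3 gives 100000 nM and is level with compound 1, the two sharing the highest of the three numbers. Compound 4 `COc1cc(/C=C/C(=O)C2=C(/C=C/c3ccc(O)c(OC)c3)NC(=S)NC2c2ccc(N(C)C)cc2)ccc1O` differs from compound 3 in one place (dimethylamino in place of hydrogen on an aromatic carbon). Within the data shown here, the one measured step that bears on this (an 8.0-fold lower number from compound 1 to compound 2 (0.90 log units; beyond the scatter)) also brings in dimethylamino, though in place of methyl rather than hydrogen. Compound 1 and compound 2 also carry a carbonyl where compound 3 and compound 4 carry a thiocarbonyl, so the comparison is imperfect. A step of similar size toward a lower number is therefore expected in this assay with wide uncertainty. The expected change (an 8.0-fold lower number from compound 3 to compound 4 (0.90 log units; beyond the scatter)) is only an estimate. Compound 4 is expected to give about 12500 nM (estimated range 4000 nM to 50000 nM).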

Compound 4, half-maximal inhibitory concentration: 25000 nM
Beside the measured number, compound 4's estimate is 2.0-fold (0.30 log units) below it, within the range that was stated.
By their numbers in this assay, from the lowest: compounds 2 and 4 (each within the scatter of the next); then compounds 1 and 3 (each within the scatter of the next).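

In this assay, changing phenyl to 4-(dimethylamino)phenyl gives a 4.0-fold lower number from compound 3 to compound 4 (0.60 log units; beyond the scatter). The earlier step, an 8.0-fold lower number from compound 1 to compound 2 (0.90 log units; beyond the scatter), brought in dimethylamino in place of methyl on a core with a carbonyl. This new step shows the same direction in place of hydrogen on a core with a thiocarbonyl, so the lower number is not confined to one pair. Nothing available explains why dimethylamino has this effect. The compounds shown leave open whether a different group at this position, such as a primary amine or a methoxy group, would also lower the number.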